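Hydroxy in Place of Benzoyloxy on a Nucleotide Prodrug

The compounds below may be only part of what the source reports. "The series", "measured", "known", "first", "only" and "open" are said of these compounds alone.

Measured so far:
compound 1 `O=C(O[C@H]1C[C@H](n2cc(F)c(=O)[nH]c2=O)O[C@@H]1COP(=O)(O)Oc1cccnc1)c1ccccc1`: 6.7 h
compound 2 `C[n+]1cccc(OP(=O)([O-])OC[C@H]2O[C@@H](n3cc(F)c(=O)[nH]c3=O)C[C@@H]2OC(=O)c2ccccc2)c1`: 14.8 h
compound 3 `C[N+]1(C)CCC(OP(=O)([O-])OC[C@H]2O[C@@H](n3cc(F)c(=O)[nH]c3=O)C[C@@H]2OC(=O)c2ccccc2)CC1`: > 120 h

In a physicochemical assay for metabolic stability, read by HPLC, tested at 2 mM (a lower number here means that the compound disappears faster, a higher number that the compound lasts longer), compound 1 gives 6.7 h, the lowest of the two plain numbers. Its nearest neighbour is compound 2, reached by a 2.2-fold higher number from compound 1 to compound 2 (0.34 log units; beyond the scatter). For compound 3 the assay reports only a limit, > 120 h, which is the limit of > 120 h in this assay, at which 1 of the 3 values shown sits. The remaining steps, an at least 17-fold higher number from compound 1 to compound 3 (1.25 log units; beyond the scatter) and an at least 8.1-fold higher number from compound 2 to compound 3 (0.90 log units; beyond the scatter), also exchange the group at the phosphate end of the shared core.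

Compound 4 `O=c1[nH]c(=O)n([C@H]2C[C@H](O)[C@@H](COP(=O)(O)Oc3cccnc3)O2)cc1F` differs from compound 1 in another place: hydrogen in place of benzoyl on an oxygen on a saturated carbon. Read one bond further out, benzoyloxy becomes hydroxy. Going by the values given here, none of the measured steps touches this position; all three alter the phosphate side, so none of them bears on removing the benzoyl. Among the compounds with values here, with no comparable step to lean on, no change beyond the scatter is expected, only an estimate of a 1.2-fold higher number from compound 1 to compound 4 (0.08 log units; within the scatter). Compound 4 is therefore estimated to give 8 h, with a likely range from 3 h to 25 h.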

Compound 4, half-life: 16.7 h
Estimate against measurement, compound 4: 2.1-fold (0.32 log units) below; low and high end bracket the measured number.
By their numbers in this assay, from the lowest: compound 1; then compounds 2 and 4 (each within the scatter of the next). At a limit, above all of these: compound 3.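

Taking the benzoyl off the oxygen on a saturated carbon, so that benzoyloxy becomes hydroxy, gives a 2.5-fold higher number from compound 1 to compound 4 (0.40 log units; beyond the scatter) in this assay. This is the only step shown that leaves the phosphate side of the shared core untouched, and it shows that this position also affects how long the compound lasts, by a modest step that lies beyond the scatter. Nothing at hand accounts for the size or direction of this step.

Still open, as far as these compounds go, is whether the same change would give a similar step with the phosphate-side groups of compound 2 or compound 3. Also open, from the compounds shown here alone, is how this assay would read with an acetyl in place of the benzoyl on that oxygen, or with an amine in place of the hydroxy.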